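A Second Trifluoromethyl Group Added to Compound 3

The source may hold more compounds than are shown below. What is called first, only, known or untested is meant among the compounds shown, and "the series" means these compounds.

Measured compounds in a functional assay on HeLa cells (Homo sapiens) for inhibition, read by MTT assay, with a stated time of 72 h; a higher number here means a weaker inhibitor, a lower number a stronger inhibitor:
Compound 1 `CNc1nc(C)c(C(=O)N/N=C/c2cccc(C(F)(F)F)c2)s1` gives the limit > 100 ug/mL.
Compound 2 `CNc1nc(C)c(C(=O)N/N=C/c2cc(C(F)(F)F)cc(C(F)(F)F)c2)s1` gives the limit > 100 ug/mL.
Compound 3 `CN(C(=O)NC(=O)c1ccc(C(F)(F)F)cc1)c1nc(C(F)(F)F)c(C(=O)N/N=C/c2cccc(C(F)(F)F)c2)s1` gives 6.2 ug/mL.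

The change from compound 1 to compound 2 is trifluoromethyl in place of hydrogen on an aromatic carbon. Its size is a step that the two limits leave unreadable from compound 1 to compound 2, because of the limit of > 100 ug/mL in this assay, at which 2 of the 3 values shown sit. The difference between the core of compound 1 and the core of compound 3 is not broken down here.

Compound 4 `CN(C(=O)NC(=O)c1ccc(C(F)(F)F)cc1)c1nc(C(F)(F)F)c(C(=O)N/N=C/c2cc(C(F)(F)F)cc(C(F)(F)F)c2)s1` is yet to be measured in this assay. It differs from compound 3 by trifluoromethyl in place of hydrogen on an aromatic carbon, the same change as that from compound 1 to compound 2. Since that earlier step could not be read, the expectation for compound 4 rests only on the value of compound 3, 6.2 ug/mL, and the expected step is a 1.0-fold lower number from compound 3 to compound 4 (0.01 log units; within the scatter). Compound 4 is estimated at 6 ug/mL, between 2 ug/mL and 25 ug/mL.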

Compound 4, half-maximal inhibitory concentration: 5.78 ug/mL
Compound 4: the middle estimate sits 1.0-fold (0.02 log units) above what was measured, within the range that was stated.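

The step measured in this assay is a 1.1-fold lower number from compound 3 to compound 4 (0.03 log units; within the scatter), so the added trifluoromethyl group leaves the number within the scatter on this core. On the core of compound 1 the same change cannot be read, since compound 1 and compound 2 each give only a limit of the assay and no number: the limit of > 100 ug/mL in this assay, at which 2 of the 4 values shown sit. The change can therefore be read on one core only, and the data do not show whether it behaves alike on both.

The compounds shown leave open whether a different group in the place of the added trifluoromethyl, such as an amine or a carboxylic acid, would move the number beyond the scatter. They also leave open whether a nitrile there would do so.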